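The source may hold more compounds than are shown below. What is called first, only, known or untested is meant among the compounds shown, and "the series" means these compounds.

Measured compounds:
compound 1 `CN(C)c1ccc(N2C(=O)NC3(CSC4=C3C(=O)c3ncccc3C4=O)C2=O)cc1`: 800 nM
compound 2 `CCCc1ccc(N2C(=O)NC3(CSC4=C3C(=O)c3ncccc3C4=O)C2=O)cc1`: 450 nM
compound 3 `O=C1C2=C(C(=O)c3ncccc31)C1(CS2)NC(=O)N(c2ccccc2)C1=O`: 1510 nM

All three were tested in a functional assay on XF498 cells (Homo sapiens) for antiproliferative activity, read by MTT assay, with a stated time of 96 h; a lower number here means a stronger inhibitor, a higher number a weaker inhibitor. Compound 1 stands second highest of the three numbers, and both a 1.8-fold lower number from compound 1 to compound 2 (0.25 log units; within the scatter) and a 1.9-fold higher number from compound 1 to compound 3 (0.28 log units; within the scatter) fall within the scatter. Only a 3.4-fold higher number from compound 2 to compound 3 (0.53 log units; beyond the scatter) goes beyond it, and modestly.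

Compound 4 `Cc1ccc(N2C(=O)NC3(CSC4=C3C(=O)c3ncccc3C4=O)C2=O)cc1` has not yet been measured. methyl in place of dimethylamino on an aromatic carbon Methyl lies between the hydrogen of compound 3 and the propyl of compound 2 at the same ring carbon, and both measured exchanges at that spot starting from compound 1 stayed within the scatter, so no step beyond the scatter is expected for compound 4 in this assay. For compound 4 the estimate is 700 nM, with an expected range from 350 nM to 1500 nM. The step this estimate implies is a 1.1-fold lower number from compound 1 to compound 4 (0.06 log units; within the scatter).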

Compound 4, half-maximal inhibitory concentration: 1350 nM
The estimate for compound 4 lay 1.9-fold (0.29 log units) below the measured number, within the range that was stated.
By their numbers in this assay, from the lowest: compounds 2, 1, 4 and 3 (each within the scatter of the next, the first and the last beyond it).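

Methyl at this ring carbon cannot be told apart from hydrogen (a 1.1-fold lower number from compound 3 to compound 4 (0.05 log units; within the scatter)) or from dimethylamino (a 1.7-fold higher number from compound 1 to compound 4 (0.23 log units; within the scatter)) in this assay. Propyl alone stands apart from methyl (a 3.0-fold higher number from compound 2 to compound 4 (0.48 log units; beyond the scatter)), so here the lower number goes with the propyl chain, although dimethylamino in compound 1 lies within the scatter of both compound 2 and compound 4. No measurement shown explains this difference.

From the compounds shown here alone, whether an ethyl or butyl chain at this carbon would give a number like that of propyl stays open, as does where a carboxylic acid there would fall.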